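The compounds below may be only part of what the source reports. "The series", "measured", "known", "first", "only" and "open" are said of these compounds alone.

Compound 1 `O=C(Nc1cc(-c2ccccc2)[nH]n1)c1ccc(Br)nc1` is the reference point of this small set. In a functional assay on WM1361 cells (Homo sapiens) for antiproliferative activity, read by MTT assay, with a stated time of 48 h (on this read-out higher numbers stand for weaker inhibition and lower numbers for stronger inhibition), compound 1 gives 19400 nM. Compound 2 `O=C(Nc1cc(-c2ccccc2)[nH]n1)c1ccc(Cl)nc1` differs from it only by chloro in place of bromo on an aromatic carbon, and in this assay compound 2 gives 19000 nM; the step of a 1.0-fold lower number from compound 1 to compound 2 (0.01 log units; within the scatter) is one the assay cannot distinguish from no change. Compound 3 `Cc1ccc(-c2cc(NC(=O)c3ccc(Br)nc3)n[nH]2)cc1` keeps the halogen of compound 1 but carries methyl in place of hydrogen on an aromatic carbon on the carbon-only ring, and in this assay compound 3 gives 18600 nM. The three numbers sit within the ordinary scatter of one another, so none of the three can be ranked against the others on this read-out.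

Compound 4 `Cc1ccc(-c2cc(NC(=O)c3ccc(Cl)nc3)n[nH]2)cc1` has not yet been measured. Relative to compound 3 it differs by chloro in place of bromo on an aromatic carbon. Within the data shown here, this is the same change as the one from compound 1 to compound 2, made at the same place on the same ring; the two pairs differ only in their cores, by the methyl group already described. Among the measured compounds shown here, the single precedent for the change is the step of a 1.0-fold lower number from compound 1 to compound 2 (0.01 log units; within the scatter), which stayed within the scatter. For compound 4 the expected step is therefore a 1.0-fold lower number from compound 3 to compound 4 (0.00 log units; within the scatter), resting on the observation that a 1.0-fold lower number from compound 1 to compound 2 (0.01 log units; within the scatter) produced no shift in the core of compound 1. Compound 4 is accordingly estimated at 18500 nM, with a likely range from 10000 nM to 35000 nM.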

Compound 4, half-maximal inhibitory concentration: 16700 nM
Compound 4: the middle estimate sits 1.1-fold (0.04 log units) above what was measured, within the range that was stated.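

In this assay, chloro in place of bromo gives a 1.1-fold lower number from compound 3 to compound 4 (0.05 log units; within the scatter), and this step on the methyl-bearing core matches the one on the core of compound 1: the same change on two cores in this assay, a 1.0-fold lower number (0.01 log units; within the scatter) from compound 1 to compound 2 and a 1.1-fold lower number (0.05 log units; within the scatter) from compound 3 to compound 4, 1.1-fold (0.04 log units) apart, within the scatter of two such steps. Methyl in place of hydrogen on the carbon-only ring, now with chloro as the halogen, gives a 1.1-fold lower number from compound 2 to compound 4 (0.06 log units; within the scatter), and it too matches its earlier counterpart with bromo as the halogen: the same change on two cores in this assay, a 1.0-fold lower number (0.02 log units; within the scatter) from compound 1 to compound 3 and a 1.1-fold lower number (0.06 log units; within the scatter) from compound 2 to compound 4, 1.1-fold (0.04 log units) apart, within the scatter of two such steps. Across these four compounds, then, each change carries from one core to the other without any shift the assay can detect, but since all four steps lie within the scatter, this is agreement between steps that cannot be told from no change, and it does not show that either change has any effect of its own, nor how a change that did move the number would transfer between cores.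

The compounds shown leave open whether an amine or a carboxylic acid in place of the halogen, or a methoxy group or a longer chain in place of the methyl, would move the number beyond the scatter. They also leave open whether two such changes would still add up independently once one of them produced a real step.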